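The compounds below may be only part of what the source reports. "The series", "measured", "known", "first", "only" and "open" are said of these compounds alone.

In a functional assay on SK-MEL-5 cells (Homo sapiens) for inhibition, read by sulforhodamine B assay, with a stated time of 48 h (on this read-out lower numbers stand for stronger inhibition of growth and higher numbers for weaker inhibition of growth), compound 1 (`Cc1ccc(C2=NN(c3ccc(S(C)(=O)=O)cc3)C(=O)CC2)cc1`) gives > 100000 nM as a limit of the assay and not a number. Compound 2 (`Cc1cc(O)ccc1C1=NN(c2ccc(S(C)(=O)=O)cc2)C(=O)CC1`) gives > 100000 nM as a limit too. Compound 2 therefore has no exact place on this scale, and the only other result beside it is also a limit. The change to compound 3 (`CCc1ccc(C2=NN(c3ccc(S(C)(=O)=O)cc3)C(=O)CC2)cc1`) is 4-ethylphenyl in place of 4-hydroxy-2-methylphenyl on a carbon with a double bond to nitrogen. Among the measured compounds shown here, the one measured step that bears on this is a step that the two limits leave unreadable from compound 1 to compound 2 on that same kind of carbon, and it has no readable size. Both results rest on the limit of > 100000 nM in this assay, at which 2 of the 2 values shown sit, and so offer no number to scale from. With nothing to suggest a shift in either direction, no clear change is expected in this assay from this swap. The estimated a number no higher from compound 2 to compound 3 (the limit leaves the size open) is expected to stay within the usual scatter. For compound 3 the expected value is 100000 nM with an estimated range from 50000 nM to 200000 nM and a good chance that a limit rather than a number is the expected outcome.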

Compound 3, concentration for total growth inhibition: 11200 nM
Estimate against measurement, compound 3: 8.9-fold (0.95 log units) above; the whole stated range lies above it.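

In this assay, the group on the carbon with a double bond to nitrogen can bring the result out of the limit and onto the measurable scale, which compound 1 and compound 2 could not show. The smallest change shown is enough to do this: methyl in place of hydrogen on a saturated chain carbon bound to an aromatic carbon, which turns 4-methylphenyl into 4-ethylphenyl, gives an at least 8.9-fold lower number from compound 1 to compound 3 (0.95 log units; beyond the scatter), and putting 4-ethylphenyl in place of 4-hydroxy-2-methylphenyl gives an at least 8.9-fold lower number from compound 2 to compound 3 (0.95 log units; beyond the scatter). Both steps give only a minimum size, because each starts from a limit and not from a number: the limit of > 100000 nM in this assay, at which 2 of the 3 values shown sit.

The compounds shown leave open whether a longer chain at this place, such as propyl or butyl, would lower the number further or raise it again, and whether the effect depends on a chain at all or would also appear with a chlorine or a methoxy group on the same phenyl ring. On these data alone, the step between compound 1 and compound 2 cannot be read, so the effect of the hydroxy and methyl groups of compound 2 also stays unknown.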